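A Difluorophenyl Group Replaces a Fluorinated Ether Chain

The source may report more compounds than this note shows. Statements on the series, on what has been measured and on what is new or still open speak of the compounds shown alone.

In a functional assay on the whole organism for inhibition, with Mus musculus as the target, with a stated time of 60 min (a higher number here means that more compound is needed for the effect, a lower number that less compound is needed), compound 1 `CC(C)Oc1ccc(S(C)(=O)=O)cc1C(=O)N1Cc2cc(C(F)(F)F)cnc2C1` gives 1 mg/kg, and compound 2 `CS(=O)(=O)c1ccc(OCCC(F)(F)F)c(C(=O)N2Cc3cc(C(F)(F)F)cnc3C2)c1` gives 3 mg/kg. Compound 2 therefore has the higher of the two numbers, meaning that more of it is needed for the effect.

Compound 3 `CS(=O)(=O)c1ccc(-c2ccc(F)c(F)c2)c(C(=O)N2Cc3cc(C(F)(F)F)cnc3C2)c1` carries 3,4-difluorophenyl in place of 3,3,3-trifluoropropoxy on an aromatic carbon. This carbon is ortho to a large group and para to a methylsulfonyl group.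

Among the compounds with values here, only one measured step bears on this change. Putting 3,3,3-trifluoropropyl in place of isopropyl on an oxygen on an aromatic ring gave a 3.0-fold higher number from compound 1 to compound 2 (0.48 log units; beyond the scatter), a modest step. That step altered only the chain on the oxygen, whereas here the oxygen goes too and a ring enters, so it is a weak guide. Within the data shown here, no measured compound has a ring at this place. A step of similar modest size, again towards a higher number, is the cautious expectation, estimated as a 2.7-fold higher number from compound 2 to compound 3 (0.43 log units; beyond the scatter). For compound 3 the estimated value is 8 mg/kg, with an expected range from 2 mg/kg to 30 mg/kg.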

Compound 3, dose for 50% inhibition: 1 mg/kg
Compound 3: the middle estimate sits 8.0-fold (0.90 log units) above what was measured; the measured number lies below the stated range.
By their numbers in this assay, from the lowest: compounds 1 and 3 (each within the scatter of the next); then compound 2.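

In this assay this aromatic carbon, ortho to a large group and para to a methylsulfonyl group, proves able to carry a whole ring with no oxygen attached: 3,4-difluorophenyl in place of 3,3,3-trifluoropropoxy gives a 3.0-fold lower number from compound 2 to compound 3 (0.48 log units; beyond the scatter), a modest step towards less compound being needed. Compared with the isopropoxy group, the same ring gives no change at the digits printed from compound 1 to compound 3 (within the scatter), so these two very different groups cannot be told apart in this test, and among the three compounds only compound 2 stands apart from the others. Nothing available here accounts for the step from the fluorinated ether chain to the ring.

Still open, as far as these compounds go, is how a plain phenyl ring, a pyridine ring or an amine such as morpholine would compare with 3,4-difluorophenyl at this carbon, which would show whether the two fluorine atoms or the carbon-only ring have any bearing on the result. Also open, from the compounds shown here alone, is whether the result would hold with a nitrile in place of the methylsulfonyl group or of the trifluoromethyl group on the shared core.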